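Acetylating the amine of compound 3: an expected gain

This account rests on a few compounds, and the source may have more. Where it says the series, first, only, none or still open, it means among the compounds named here.

Three compounds share a sulfonamide core. Compound 1 `Cc1noc(NS(=O)(=O)c2cccc3ccc(N(C)C)cc23)c1C` gives 5600 nM in an assay on thoracic aorta for binding affinity to Endothelin-1 receptor (Rattus norvegicus); a higher number here means a weaker inhibitor, a lower number a stronger inhibitor. Compound 2 `CC(=O)Nc1cccc2cc(S(=O)(=O)Nc3onc(C)c3C)ccc12` gives 2700 nM in this assay. Compound 3 `Cc1noc(NS(=O)(=O)c2ccc3ccc(N)cc3c2)c1C` gives 10000 nM in this assay, the highest of the three numbers; its nearest neighbour is compound 1, within the scatter, while compound 2 sits beyond the scatter with a lower number.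

Compound 4 `CC(=O)Nc1ccc2ccc(S(=O)(=O)Nc3onc(C)c3C)cc2c1` is not yet measured. It differs from compound 3 by acetyl in place of hydrogen on a nitrogen on an aromatic ring, or amino to acetamido. Within the data shown here, no measured pair shows this exact step. Compound 2 also carries an acetamido group and gives a lower number than compound 3, but its ring arrangement differs, so that pair only shows what two values show.

Compound 4 is therefore expected to show a modest gain, a step of a 2.2-fold lower number from compound 3 to compound 4 (0.35 log units; beyond the scatter), with an estimate of 4500 nM ranging from 1500 nM to 13000 nM in this assay.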

Compound 4, half-maximal inhibitory concentration: 42000 nM
For compound 4 the middle estimate is 9.3-fold (0.97 log units) below the measured one; measured number above the stated range.
By their numbers in this assay, from the lowest: compound 2; then compounds 1 and 3 (each within the scatter of the next); then compound 4.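

In this assay the change from amino to acetamido gives a 4.2-fold higher number from compound 3 to compound 4 (0.62 log units; beyond the scatter), so acetyl in place of hydrogen on this nitrogen weakens binding, by a step beyond the scatter. Among these compounds, this is the first pair here that differs in one place, and so the first direct reading of any single change on the shared core; the earlier compounds offered only separate values. Nothing at hand accounts for the loss.

Going by these compounds, it remains open whether the loss belongs to acetyl itself or would also follow from another group on this nitrogen, such as methyl, methanesulfonyl or a longer acyl chain like propanoyl. The free amine matching compound 2 would show whether the same step holds when the acetamido group sits as it does in that compound.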